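Swapping the aryl group on a piperazine: predicting a thiol

This account rests on a few compounds, and the source may have more. Where it says the series, first, only, none or still open, it means among the compounds named here.

Measured compounds:
- compound 1, `Cn1c(=O)cnn(CCCCN2CCN(c3ccccc3OCCCF)CC2)c1=O`, 280 nM
- compound 2, `Cn1c(=O)cnn(CCCCN2CCN(c3ccccc3C#N)CC2)c1=O`, 7.3 nM
- compound 3, `Cn1c(=O)cnn(CCCCN2CCN(c3ccccn3)CC2)c1=O`, 262 nM

These three compounds share a core and differ only in the group attached to the ring nitrogen of the piperazine. In an assay for displacement of a labelled ligand from Adrenergic receptor alpha-1 (Homo sapiens) (a higher number here means a weaker inhibitor, a lower number a stronger inhibitor), compound 3 gives 262 nM, the second highest number of the three, close to compound 1 and far from compound 2.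

Compound 4, `Cn1c(=O)cnn(CCCCN2CCN(c3ccccc3S)CC2)c1=O`, has not been measured. It differs from compound 3 in one place: 2-sulfanylphenyl in place of pyridin-2-yl on an amine nitrogen in a ring.

For the measured compounds named here, two measured steps bear on this change. The step of a 38-fold lower number from compound 1 to compound 2 (1.58 log units; beyond the scatter) shows that a small group on the phenyl ring can bring a much lower number. The step of a 36-fold higher number from compound 2 to compound 3 (1.55 log units; beyond the scatter) shows that removing the substituted phenyl ring in favour of pyridin-2-yl raises the number again by a similar size. Compound 4 restores a phenyl ring carrying a small group, so a lower number than compound 3 is expected, though a smaller gain than for the cyano group cannot be ruled out.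

For compound 4 the expected value in this assay is 70 nM, in a range from 12 nM to 400 nM, an expected step of a 3.7-fold lower number from compound 3 to compound 4 (0.57 log units; beyond the scatter).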

Compound 4, inhibition constant: > 10000 nM
Compound 4: a limit, no number; the forecaster's own chance of this, stated with the estimate: 5%; middle value at least 140-fold (2.15 log units) away from the limit.
By their numbers in this assay, from the lowest: compound 2; then compounds 3 and 1 (each within the scatter of the next). At a limit, above all of these: compound 4.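

In this assay compound 4 gives only a limit of the assay, not a number: the limit of > 10000 nM in this assay, at which 1 of the 4 values shown sits. Putting 2-sulfanylphenyl on the piperazine nitrogen in place of pyridin-2-yl gives an at least 38-fold higher number from compound 3 to compound 4 (1.58 log units; beyond the scatter), so a phenyl ring carrying a small group does not by itself bring a low number. The group on that ring decides the outcome: sulfanyl in place of cyano gives an at least 1300-fold higher number from compound 2 to compound 4 (3.13 log units; beyond the scatter), and sulfanyl in place of 3-fluoropropoxy gives an at least 35-fold higher number from compound 1 to compound 4 (1.55 log units; beyond the scatter), so even the much larger group compares favourably.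

The compounds shown leave open whether this drop is particular to sulfanyl or extends to other small groups. A hydroxyl, a methoxy or an amine in the same place on the phenyl ring would help to separate these possibilities.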